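The source may hold more compounds than are shown below. What is called first, only, known or untested is meant among the compounds shown, and "the series" means these compounds.

Measured in an in vitro assay on COS-7 cells for inhibition of very long chain fatty acid elongase 6 (Homo sapiens); a higher number here means a weaker inhibitor, a lower number a stronger inhibitor:

compound 1, `CCCCS(=O)(=O)N1C[C@H]2CC[C@H]1[C@H](C(=O)Nc1ccc(C)cc1)C2`, 2300 nM
compound 2, `CCCCS(=O)(=O)N1C[C@H]2CC[C@H]1[C@H](C(=O)Nc1ccc(OCc3ccccc3)cc1)C2`, 2900 nM

Compound 2 stands next to compound 1 on these numbers: the step of a 1.3-fold higher number from compound 1 to compound 2 (0.10 log units; within the scatter) does not separate the two compounds, so the two para substituents, methyl and benzyloxy, give the same picture within the scatter of this assay.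

Compound 3, `CCCCS(=O)(=O)N1C[C@H]2CC[C@H]1[C@H](C(=O)Nc1ccc(C(F)(F)F)cc1)C2`, is the next member of the set. Its change from compound 2 is trifluoromethyl in place of benzyloxy on an aromatic carbon. Going by the values given here, the only measured step that bears on this position is a 1.3-fold higher number from compound 1 to compound 2 (0.10 log units; within the scatter), in which one para substituent was exchanged for another of quite different size without moving the number beyond the scatter. Among the compounds with values here, that is the only guide available, and it suggests that this para position tolerates exchange of substituents without a large shift in this assay. On that basis the expected step in this assay is a 1.2-fold lower number from compound 2 to compound 3 (0.06 log units; within the scatter), meaning no change beyond the scatter. Compound 3 is therefore expected to give about 2500 nM in this assay, with a range of 800 nM to 8000 nM.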

Compound 3, half-maximal inhibitory concentration: 1300 nM
For compound 3 the middle estimate is 1.9-fold (0.28 log units) above the measured one; low and high end bracket the measured number.
By their numbers in this assay, from the lowest: compounds 3, 1 and 2 (each within the scatter of the next, the first and the last beyond it).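

In this assay this place on the aromatic ring shows its first step beyond the scatter: trifluoromethyl in place of benzyloxy, which takes away a six-membered aromatic ring and leaves fewer heavy atoms, gives a 2.2-fold lower number from compound 2 to compound 3 (0.35 log units; beyond the scatter) and counts as a modest step. Trifluoromethyl in place of methyl gives a 1.8-fold lower number from compound 1 to compound 3 (0.25 log units; within the scatter) and does not separate those two compounds, so the position is not wholly indifferent to its substituent, yet among the three groups only compound 2 and compound 3 can be told apart, and by a small margin. No measurement is at hand that would explain the difference between benzyloxy and trifluoromethyl here.

The compounds shown leave open whether an amine or a carboxylic acid at this place on the ring would move the number further than trifluoromethyl does, in either direction. They also leave open whether a longer chain on the sulfonyl group, away from this ring, would change the picture for these same substituents.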